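The source may hold more compounds than are shown below. What is called first, only, known or untested is meant among the compounds shown, and "the series" means these compounds.

In a functional assay on HCT-116 cells (Homo sapiens) for cytotoxicity, read by MTT assay, with a stated time of 72 h (on this read-out lower numbers stand for stronger inhibition and higher numbers for weaker inhibition), the three measured compounds read as follows:

Compound 1 `Nc1cccc(Nc2c(C(=O)NCc3ccc(F)cc3)nc(Br)c3cccnc23)c1` gives > 10000 nM as a limit
Compound 2 `O=C(NCc1ccc(F)cc1)c1nc(Br)c2cccnc2c1N1CCNCC1` gives > 10000 nM as a limit
Compound 3 `O=C(NCc1ccc(F)cc1)c1nc(Br)c2cccnc2c1NCc1ccccc1` gives > 20000 nM as a limit

Compound 3 therefore stands on a limit and not on a number, as do the other two compounds. The series offers only the limit of > 10000 nM in this assay, at which 2 of the 3 values shown sit, and the limit of > 20000 nM in this assay, at which 1 of the 3 values shown sits, as its readings.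

Compound 4 `COC(=O)CNc1c(C(=O)NCc2ccc(F)cc2)nc(Br)c2cccnc12` has not yet been measured. Its difference from compound 3 is methoxycarbonyl in place of phenyl on a saturated chain carbon bound to a nitrogen on an aromatic ring and in words it is methoxycarbonyl in place of phenyl on a saturated chain carbon bound to a nitrogen on an aromatic ring.

Among the measured compounds shown here, two measured steps bear on this substituent. They are a step that the two limits leave unreadable from compound 1 to compound 3 and a step that the two limits leave unreadable from compound 2 to compound 3 and neither offers a size or a direction to carry over. Compound 3, at > 20000 nM as a limit, gives no number to start from, so no step beyond the scatter is expected. The expected step is a number no higher from compound 3 to compound 4 (the limit leaves the size open) and it remains an estimate. For compound 4 the estimated value is 20000 nM with an expected range from 8000 nM to 50000 nM in this assay and a report as a limit alone is the likeliest outcome.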

Compound 4, half-maximal inhibitory concentration: > 10000 nM
Compound 4 ended at the assay's limit; the forecaster's own chance of this, stated with the estimate: 80%; the middle value lies beyond the limit too.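

In this assay compound 4 gives > 10000 nM, which is a limit and not a number. Among the compounds shown here, with compound 1, compound 2 and compound 3 also on limits, no step from any of them to compound 4 can be read. The compounds shown leave open whether any substituent at this place on the shared core gives a measurable value.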